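Lengthening a Side Chain at the Weak End of the Series

This account rests on a few compounds, and the source may have more. Where it says the series, first, only, none or still open, it means among the compounds named here.

Three measured compounds share one core and differ only in the group attached to a saturated chain carbon bound to an amine nitrogen in a ring. Compound 1 `COc1ccc2nccc(C3CN(C4CCN(Cc5cc6ccccc6[nH]5)CC4)C(=O)O3)c2c1` carries a 1H-indol-2-yl group there, and in an in vitro functional assay on RBL cells for antagonist activity at C-C chemokine receptor type 8 (Homo sapiens), read by FLIPR and calcium flux (a higher number here means a weaker inhibitor, a lower number a stronger inhibitor), compound 1 gives 25.1 nM. Compound 2 `COc1ccc2nccc(C3CN(C4CCN(Cc5c[nH]c6ccccc56)CC4)C(=O)O3)c2c1` carries a 1H-indol-3-yl group instead. For compound 2 the assay returns only a limit, < 50200 nM, rather than a number. Compound 3 `COc1ccc2nccc(C3CN(C4CCN(Cc5ccccc5)CC4)C(=O)O3)c2c1` carries a plain phenyl group, and in this assay compound 3 gives 12600 nM. Among the measured compounds shown here, of the two numbers known, compound 3 stands highest, since the step of a 500-fold higher number from compound 1 to compound 3 (2.70 log units; beyond the scatter) is large. The steps a step that the limit leaves unreadable from compound 1 to compound 2 and a step that the limit leaves unreadable from compound 2 to compound 3 cannot be sized because of the limit of < 50200 nM in this assay, at which 1 of the 3 values shown sits.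

Compound 4 `COc1ccc2nccc(C3CN(C4CCN(CCCc5ccccc5)CC4)C(=O)O3)c2c1` keeps the phenyl ring but pushes it further out: phenethyl in place of phenyl on a saturated chain carbon bound to an amine nitrogen in a ring. For the measured compounds named here, none of the measured steps alters the length of this chain; each swaps the aromatic group itself, so they give no direct guide here. For compound 4 the expected step is a 1.1-fold lower number from compound 3 to compound 4 (0.02 log units; within the scatter), a step that is expected to stay within the scatter of repeated measurement. The estimate for compound 4 in this assay is 12000 nM, with a range from 2500 nM to 50000 nM.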

Compound 4, half-maximal inhibitory concentration: 251 nM
Compound 4: middle estimate off by 48-fold (1.68 log units), on the high side; the whole stated range lies above it.
By their numbers in this assay, from the lowest: compound 1; then compound 4; then compound 3.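

The length of the link at this position matters, not only the identity of the aromatic group: with the phenyl ring itself unchanged, moving from benzyl to 3-phenylpropyl in this assay gives a 50-fold lower number from compound 3 to compound 4 (1.70 log units; beyond the scatter). A plain phenyl ring at the end of the longer chain therefore recovers much of the inhibition seen with the 1H-indol-2-yl group, so the indole is not the only route to a stronger compound in this set, although a clear gap remains, with a 10-fold higher number from compound 1 to compound 4 (1.00 log units; beyond the scatter). The steps that involve compound 2 cannot be read, because compound 2 gives only a limit and not a number: the limit of < 50200 nM in this assay, at which 1 of the 4 values shown sits.

Among the compounds shown here, only two chain lengths carrying a phenyl ring appear here, so these compounds cannot show whether inhibition keeps improving with a longer chain such as 4-phenylbutyl or is best at some other length, for example with 2-phenylethyl. They also leave open whether lengthening the chain would help or harm when the ring at its end is 1H-indol-2-yl rather than phenyl, since the effects of chain and ring have not been seen together.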